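The source may report more compounds than this note shows. Statements on the series, on what has been measured and on what is new or still open speak of the compounds shown alone.

Measured in an ADME assay on Vero cells (Chlorocebus sabaeus) for cytotoxicity, with a stated time of 5 days (a higher number here means a weaker inhibitor, a lower number a stronger inhibitor), each value a limit:
- Compound 1 `COc1nc(NC2CC2)c2ncn([C@H]3C[C@H](N=[N+]=[N-])[C@@H](CO)O3)c2n1`: > 100000 nM
- Compound 2 `CC(C)(CO)Nc1nc(N)nc2c1ncn2[C@H]1C[C@H](N=[N+]=[N-])[C@@H](CO)O1`: > 100000 nM
- Compound 3 `C=CCNc1nc(N)nc2c1ncn2[C@H]1C[C@H](N=[N+]=[N-])[C@@H](CO)O1`: > 100000 nM

Compound 2 is known only as a limit, with no number behind it, and the other two compounds stand the same way: the limit of > 100000 nM in this assay, at which 3 of the 3 values shown sit.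

Compound 4 `[N-]=[N+]=N[C@H]1C[C@H](n2cnc3c(NCCCCCO)nc(N)nc32)O[C@@H]1CO` is not yet measured. Its change from compound 2 is 5-hydroxypentyl in place of 1-(hydroxymethyl)-1-methylethyl on a nitrogen on an aromatic ring. Going by the values given here, the one measured step at this place is a step that the two limits leave unreadable from compound 2 to compound 3, and it gives no size to carry over. No shift in either direction beyond the scatter is expected in this assay. The expected change is a number no higher from compound 2 to compound 4 (the limit leaves the size open). The estimate for compound 4 is 100000 nM, with an expected range of 40000 nM to 200000 nM, and a report as a limit is the likely outcome.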

Compound 4, half-maximal inhibitory concentration: > 100000 nM
Compound 4 was reported as a limit; the forecaster's own chance of this, stated with the estimate: 85%; the middle value sits exactly at the limit.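

Neither compound 4 against compound 2 nor compound 4 against compound 3 gives a readable step in this assay, as each value is only a limit: the limit of > 100000 nM in this assay, at which 4 of the 4 values shown sit.

The compounds shown leave open whether changing the group on the nitrogen alters cytotoxicity at all.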